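Relocating the Methoxy Group of Compound 3

A few compounds are considered here, and "the series" means these few. Any claim that something is new, unique, unknown or untested is made for them only; others in the source may bear on it.

Of the compounds shown here, three sharing one core have been measured in an assay on cells for inhibition of Ectonucleotide pyrophosphatase/phosphodiesterase family member 1 (Homo sapiens), with a stated time of 60 min; on this read-out higher numbers stand for weaker inhibition and lower numbers for stronger inhibition. Compound 1 `COc1cc2nc(/C=C/c3cccnc3)nc(N3CCC(CCNS(N)(=O)=O)CC3)c2cc1OC` carries a pyridin-3-yl on the double-bonded chain carbon and gives 58 nM. Compound 2 `COc1cc2nc(/C=C/c3cccc(F)c3)nc(N3CCC(CCNS(N)(=O)=O)CC3)c2cc1OC`, with 3-fluorophenyl in that place, gives 3580 nM, and compound 3 `COc1cccc(/C=C/c2nc(N3CCC(CCNS(N)(=O)=O)CC3)c3cc(OC)c(OC)cc3n2)c1`, with 3-methoxyphenyl, gives 101 nM. Compound 3 thus stands second of the three numbers: its nearest neighbour is compound 1, a 1.7-fold higher number from compound 1 to compound 3 (0.24 log units; within the scatter), while compound 2 is far away, a 35-fold lower number from compound 2 to compound 3 (1.55 log units; beyond the scatter).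

Compound 4 `COc1ccc(/C=C/c2nc(N3CCC(CCNS(N)(=O)=O)CC3)c3cc(OC)c(OC)cc3n2)cc1` differs from compound 3 in one place: 4-methoxyphenyl in place of 3-methoxyphenyl on a double-bonded chain carbon bound to a double-bonded chain carbon. Among the measured compounds shown here, no measured step exchanges one methoxyphenyl for another, so nothing directly bears on this move. What the measured steps do show is that the substituent on this ring matters greatly, as a 62-fold higher number from compound 1 to compound 2 (1.79 log units; beyond the scatter) and a 35-fold lower number from compound 2 to compound 3 (1.55 log units; beyond the scatter) demonstrate, whereas the ring type itself matters little, as a 1.7-fold higher number from compound 1 to compound 3 (0.24 log units; within the scatter) shows. Since the methoxy group is kept, a large loss seems less likely than in the fluoro case, but the step is not bounded by any measured pair. It is therefore expected that compound 4 in this assay gives 180 nM, with a wide range from 40 nM to 900 nM, corresponding to an estimated step of a 1.8-fold higher number from compound 3 to compound 4 (0.25 log units; within the scatter).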

Compound 4, inhibition constant: 231 nM
The estimate for compound 4 lay 1.3-fold (0.11 log units) below the measured number, within the range that was stated.
By their numbers in this assay, from the lowest: compounds 1 and 3 (each within the scatter of the next); then compound 4; then compound 2.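

In this assay, 4-methoxyphenyl and 3-methoxyphenyl have the same atoms and the same counts, yet exchanging them gives a 2.3-fold higher number from compound 3 to compound 4 (0.36 log units; beyond the scatter), a modest step beyond the scatter, so at this position the placement of the methoxy group on the ring counts, and not only the presence of the group. The large gap to the 3-fluorophenyl group survives the move, with a 15-fold lower number from compound 2 to compound 4 (1.19 log units; beyond the scatter), which means that both methoxyphenyl compounds stand well apart from the fluoro compound, while the exchange of pyridin-3-yl for 4-methoxyphenyl, unlike that for 3-methoxyphenyl, now registers beyond the scatter, with a 4.0-fold higher number from compound 1 to compound 4 (0.60 log units; beyond the scatter). No measurement is at hand that explains why the placement of the methoxy group changes the number.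

The compounds shown leave open whether a fluoro group would respond to the same move as the methoxy group does, since 3-fluorophenyl is its only placement here. They also leave open how this position would take an amine, a hydroxy group or a carboxylic acid on the ring in place of methoxy.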